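Swapping a Dichlorothienyl Ring for Pyridinyl on a Fused Core

This account rests on a few compounds, and the source may have more. Where it says the series, first, only, none or still open, it means among the compounds named here.

Measured compounds:
Compound 1, `COC(=O)C1=C(C)NC(C)=C(C(=O)OC)C1c1c(-c2c(Cl)csc2Cl)nc2sc(C)cn12`: 3230 nM
Compound 2, `COC(=O)C1=C(C)NC(C)=C(C(=O)OC)C1c1c(-c2ccncc2)nc2sc(C)cn12`: 9690 nM
Compound 3, `COC(=O)C1=C(C)NC(C)=C(C(=O)OC)C1c1c(-c2c(Cl)csc2Cl)nc2sccn12`: 180 nM

All three were tested in a functional assay on ileum (Cavia porcellus) for inhibition; a lower number here means a stronger inhibitor, a higher number a weaker inhibitor. Compound 1 and compound 2 share one core, and compound 3 carries a slightly different core: the difference between them is hydrogen in place of methyl on an aromatic carbon. That small change mattered: in this assay the step is an 18-fold lower number from compound 1 to compound 3 (1.25 log units; beyond the scatter), so compound 3 gives the lowest number of the three.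

The change of interest is the replacement of the dichlorinated five-membered ring by pyridin-4-yl. Between compound 1 and compound 2 it is a group of 6 heavy atoms (5 carbon, 1 nitrogen; one six-membered aromatic ring with 1 hetero atom) in place of a group of 7 heavy atoms (4 carbon, 1 sulfur, 2 chlorine; one five-membered aromatic ring with 1 hetero atom), on an aromatic carbon, and the measured step was a 3.0-fold higher number from compound 1 to compound 2 (0.48 log units; beyond the scatter), a modest weakening.

Compound 4, `COC(=O)C1=C(C)NC(C)=C(C(=O)OC)C1c1c(-c2ccncc2)nc2sccn12`, has not yet been measured in this assay. It relates to compound 3 exactly as compound 2 relates to compound 1: the difference is a group of 6 heavy atoms (5 carbon, 1 nitrogen; one six-membered aromatic ring with 1 hetero atom) in place of a group of 7 heavy atoms (4 carbon, 1 sulfur, 2 chlorine; one five-membered aromatic ring with 1 hetero atom), on an aromatic carbon, and the place of the change is described in the same words in both pairs, so it is the same change made on the second core. The expected step is a 3.0-fold higher number from compound 3 to compound 4 (0.48 log units; beyond the scatter), because the same change on the first core gave a 3.0-fold higher number from compound 1 to compound 2 (0.48 log units; beyond the scatter). Among the compounds with values here, whether the two cores respond alike is not known from only one pair, so the range is kept wide. For compound 4 the estimate in this assay is 540 nM, expected to fall between 200 nM and 1500 nM.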

Compound 4, half-maximal inhibitory concentration: 960 nM
Beside the measured number, compound 4's estimate is 1.8-fold (0.25 log units) below it; the measured number falls inside the stated range.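

On the core without the methyl, putting pyridin-4-yl in place of the dichlorinated five-membered ring gave a 5.3-fold higher number from compound 3 to compound 4 (0.73 log units; beyond the scatter) in this assay, the same direction as on the methyl-bearing core, and the two steps agree: the same change on two cores in this assay, a 3.0-fold higher number (0.48 log units; beyond the scatter) from compound 1 to compound 2 and a 5.3-fold higher number (0.73 log units; beyond the scatter) from compound 3 to compound 4, 1.8-fold (0.25 log units) apart, within the scatter of two such steps. Read the other way, with pyridin-4-yl in place on both cores, hydrogen in place of methyl gave a 10-fold lower number from compound 2 to compound 4 (1.00 log units; beyond the scatter), so this change also carried over from the dichlorinated compounds: the same change on two cores in this assay, an 18-fold lower number (1.25 log units; beyond the scatter) from compound 1 to compound 3 and a 10-fold lower number (1.00 log units; beyond the scatter) from compound 2 to compound 4, 1.8-fold (0.25 log units) apart, within the scatter of two such steps. Within these four compounds, the two changes therefore behave as roughly independent of each other, but this rests on a single pair of cores and a single pair of ring groups in one assay, so it does not show that the same steps would hold on any other core, and it does not explain why either change alters the number.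

As far as these compounds go, whether a plain phenyl ring or a pyridin-3-yl ring would follow the same pattern on both cores remains open. So does the outcome of placing an ethyl group or a chlorine atom on the aromatic carbon that carries hydrogen in compound 3 and compound 4 and methyl in compound 1 and compound 2.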